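The source may hold more compounds than are shown below. What is called first, only, known or untested is meant among the compounds shown, and "the series" means these compounds.

The series shares a core carrying a chain that ends in a hydroxyl and a second aryl arm, and three of its members have been measured in a functional assay on MDA-MB-435 cells (Homo sapiens) for cytotoxicity; a lower number here means a stronger inhibitor of growth, a higher number a weaker inhibitor of growth. Compound 1, `OCCCCC#Cc1ccccc1C#Cc1cccs1`, gives 16600 nM. Compound 2, `CSc1ccccc1C#Cc1ccccc1C#CCCCCO`, gives 3900 nM. Compound 3, `COc1cccc(C#Cc2ccccc2C#CCCCCO)c1`, gives 1900 nM, the lowest of the three numbers in this assay. The nearest to compound 3 is compound 2, whose number lies beyond the scatter above it, and the furthest is compound 1, also beyond the scatter. For the measured compounds named here, none of these pairs differs in only one place, so no single step between measured compounds can be read off.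

Compound 4, `OCCCCC#Cc1ccccc1C#Cc1cccc(C(F)(F)F)c1`, has not yet been measured. It differs from compound 3 by trifluoromethyl in place of methoxy on an aromatic carbon. Going by the values given here, no measured pair shows what such a swap does, so the expectation rests on the standing of compound 3 alone. For compound 4 the step from compound 3 is estimated as a 1.5-fold higher number from compound 3 to compound 4 (0.17 log units; within the scatter), a small loss or no change beyond the scatter. Compound 4 is therefore expected to give about 2800 nM in this assay, within a range from 900 nM to 8000 nM.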

Compound 4, concentration for 50% growth inhibition: 16900 nM
The estimate for compound 4 lay 6.0-fold (0.78 log units) below the measured number; measured number above the stated range.
By their numbers in this assay, from the lowest: compound 3; then compound 2; then compounds 1 and 4 (each within the scatter of the next).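

In this assay, for the compounds shown here, trifluoromethyl in place of methoxy on an aromatic carbon, meta to a large group, gives an 8.9-fold higher number from compound 3 to compound 4 (0.95 log units; beyond the scatter), a step beyond the scatter and the only single change that can be read; compound 1 and compound 2 differ from the others in more than one place, so their steps cannot be read. It shows that this position is not indifferent to the group it carries, and that of these two groups, methoxy goes with the stronger inhibition of growth. Nothing shown explains the size of this step or says which feature of the exchanged groups lies behind it.

A single pair leaves open whether methoxy itself is favoured or trifluoromethyl is disfavoured, and a hydroxyl, an amine or a plain hydrogen on the same carbon would help to separate the two. On these data alone, it also remains open whether the step keeps its size with methoxy or trifluoromethyl on another carbon of the ring, or with a shorter or longer chain ending in the hydroxyl.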